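This account rests on a few compounds, and the source may have more. Where it says the series, first, only, none or still open, it means among the compounds named here.

Compound 1 `C=CC(=O)Nc1ccc(Cn2nc(-c3ccc(Oc4ccccc4)cc3)cc2C(=O)O)cc1`, compound 2 `O=C(CCl)Nc1ccc(Cn2nc(-c3ccc(Oc4ccccc4)cc3)cc2C(=O)O)cc1` and compound 3 `C=CC(=O)Nc1cccc(Cn2nc(-c3ccc(Oc4ccccc4)cc3)cc2CO)c1` were all tested in a functional assay on JeKo-1 cells (Homo sapiens) for inhibition, read by luminescence and CellTiter-Glo, with a stated time of 72 h; on this read-out higher numbers stand for weaker inhibition and lower numbers for stronger inhibition. For compound 1 the assay reports only a limit, > 60000 nM, at the limit (the limit of > 60000 nM in this assay, at which 1 of the 3 values shown sits). Compound 2 gives 2500 nM, so the step of an at least 24-fold lower number from compound 1 to compound 2 (1.38 log units; beyond the scatter) follows from the change (chloromethyl in place of vinyl on a carbonyl carbon). Compound 3 gives 5200 nM in this assay; how its core differs from the core of compound 1 is not broken down here. Going by the values given here, compound 4 `O=C(CCl)Nc1cccc(Cn2nc(-c3ccc(Oc4ccccc4)cc3)cc2CO)c1` has not been measured; it differs from compound 3 by chloromethyl in place of vinyl on a carbonyl carbon, the same change at the same place as the one from compound 1 to compound 2. Resting on that earlier step, compound 4 is expected to show a step of about a 5.2-fold lower number from compound 3 to compound 4 (0.72 log units; beyond the scatter) in this assay. Compound 4 is therefore estimated at 1000 nM, between 300 nM and 4000 nM.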

Compound 4, half-maximal inhibitory concentration: 400 nM
Compound 4: the middle estimate sits 2.5-fold (0.40 log units) above what was measured; the range from low to high includes it.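

On a second core, chloromethyl in place of vinyl on a carbonyl carbon again gives a large change in this assay, with a 13-fold lower number from compound 3 to compound 4 (1.11 log units; beyond the scatter). The change therefore lowers the number on both cores shown, but this does not establish that it does so by the same amount: the same change on two cores in this assay, an at least 24-fold lower number (1.38 log units; beyond the scatter) from compound 1 to compound 2 and a 13-fold lower number (1.11 log units; beyond the scatter) from compound 3 to compound 4; the limit leaves it open whether they differ. For compound 1 the value > 60000 nM is a limit of the assay, so these two pairs support only a shared direction, not a shared size, and say nothing of cores beyond these two.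

The compounds shown leave open whether the step would hold on a core carrying an ester or an amine. Also open, on these data alone, is how bromomethyl or ethyl would read on the same carbonyl carbon.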